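A Methyl Group on the Saturated Ring of Compound 2

The source may hold more compounds than are shown below. What is called first, only, known or untested is meant among the compounds shown, and "the series" means these compounds.

Compound 1, `Cc1nc(CN2CCCCC2c2ccccn2)cc(N2CCN(C)CC2)n1`: 620 nM
Compound 2, `Cc1nc(CN2CCCC2c2ccccn2)cc(N2CCN(C)CC2)n1`: 319 nM

In an assay on HPBALL cells for binding affinity to C-X-C chemokine receptor type 4 (Homo sapiens), read by flow cytometry, with a stated time of 3 h (on this read-out higher numbers stand for weaker inhibition and lower numbers for stronger inhibition), compound 2 gives 319 nM, the lowest of the two numbers measured. Compound 1 gives 620 nM in this assay, and the two values lie within the scatter of each other, so neither stands apart. Compound 3, `Cc1nc(CN2CCC(C)C2c2ccccn2)cc(N2CCN(C)CC2)n1`, differs from compound 2 by methyl in place of hydrogen on a saturated ring carbon, next to the ring atom that bears a pyridin-2-yl group. Among the measured compounds shown here, no comparable step has been measured, so no shift beyond the scatter is expected in either direction. Compound 3 is estimated at 350 nM, between 120 nM and 1000 nM. That estimate means an expected step of a 1.1-fold higher number from compound 2 to compound 3 (0.04 log units; within the scatter), within the scatter.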

Compound 3, half-maximal inhibitory concentration: 1550 nM
Beside the measured number, compound 3's estimate is 4.4-fold (0.65 log units) below it; measured number above the stated range.
By their numbers in this assay, from the lowest: compounds 2 and 1 (each within the scatter of the next); then compound 3.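

In this assay, methyl in place of hydrogen on this saturated ring carbon gives a 4.9-fold higher number from compound 2 to compound 3 (0.69 log units; beyond the scatter) and so shows that the position does not take the added group freely. This one methyl group moves the number beyond the scatter, whereas compound 1 and compound 2 stayed within the scatter of each other. Nothing at hand explains the weaker inhibition. Whether this holds only for methyl stays open, since the compounds shown do not say how a hydroxyl or an ethyl group on this carbon would behave.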